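This account rests on a few compounds, and the source may have more. Where it says the series, first, only, none or still open, it means among the compounds named here.

Compound 3 `CC(C)NC(=S)SCC1=CCOC1=O` gives 134000 nM in a functional assay on MCF7 cells (Homo sapiens) for antiproliferative activity, read by MTT assay, with a stated time of 72 h (a higher number here means a weaker inhibitor, a lower number a stronger inhibitor), a number that sits at the top of the three measured, yet the gaps a 1.1-fold higher number from compound 1 to compound 3 (0.04 log units; within the scatter) and a 1.4-fold higher number from compound 2 to compound 3 (0.15 log units; within the scatter) both fall within the scatter, so the three compounds cannot be told apart. Compound 1 `CCN(CC)C(=S)SCC1=CCOC1=O` gives 121000 nM and compound 2 `O=C1OCC=C1CSC(=S)NC1CC1` gives 94900 nM. Compound 4 `O=C1OCC=C1CSC(=S)N1CCCC1` carries pyrrolidin-1-yl in place of isopropylamino on a thiocarbonyl carbon. Among the compounds with values here, the closest precedent is the step of a 1.1-fold higher number from compound 1 to compound 3 (0.04 log units; within the scatter), where isopropylamino replaced diethylamino; the steps of a 1.3-fold lower number from compound 1 to compound 2 (0.11 log units; within the scatter) and a 1.4-fold higher number from compound 2 to compound 3 (0.15 log units; within the scatter) likewise stayed within the scatter. A change no larger than the scatter is therefore expected for compound 4 a 1.1-fold lower number from compound 3 to compound 4 (0.05 log units; within the scatter). In this assay compound 4 is estimated at 120000 nM, with a range from 60000 nM to 240000 nM.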

Compound 4, half-maximal inhibitory concentration: 56400 nM
Compound 4: middle estimate off by 2.1-fold (0.33 log units), on the high side, outside the stated range (below it).
By their numbers in this assay, from the lowest: compounds 4, 2, 1 and 3 (each within the scatter of the next, the first and the last beyond it).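

In this assay, within the data shown here, pyrrolidin-1-yl on the thiocarbonyl carbon gives the first modest steps at this position that go beyond the scatter, both to a lower number (a 2.4-fold lower number from compound 3 to compound 4 (0.38 log units; beyond the scatter); a 2.1-fold lower number from compound 1 to compound 4 (0.33 log units; beyond the scatter)). The step from the cyclopropylamino group stays within the scatter (a 1.7-fold lower number from compound 2 to compound 4 (0.23 log units; within the scatter)), so compound 4 cannot be ranked against compound 2. No measurement shown explains these steps.

On these data alone, whether this depends on ring size remains open. An azetidine or piperidine ring at the same place could show whether a smaller or larger ring gives a similar number.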